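This account rests on a few compounds, and the source may have more. Where it says the series, first, only, none or still open, it means among the compounds named here.

In a functional assay on OVCAR-5 cells (Homo sapiens) for inhibition, read by sulforhodamine B assay, with a stated time of 48 h (on this read-out higher numbers stand for weaker inhibition of growth and lower numbers for stronger inhibition of growth), compound 1 `COc1cc(-c2cc(/C=C/C(=O)c3ccc(N)cc3)[nH]n2)cc(OC)c1OC` gives 1780 nM. Among the compounds with values here, only one other compound has been measured so far: compound 2 `COc1ccc(-c2cc(/C=C/C(=O)c3cc(OC)c(OC)c(OC)c3)[nH]n2)cc1OC`, which in this assay gives 1760 nM. The two numbers are indistinguishable within the usual scatter of this kind of measurement, so neither compound can be called the stronger inhibitor of growth. Compound 3 `COc1ccc(C(=O)/C=C/c2cc(-c3cc(OC)c(OC)c(OC)c3)n[nH]2)cc1OC` has not yet been measured. It differs from compound 1 in one place: 3,4-dimethoxyphenyl in place of 4-aminophenyl on a carbonyl carbon. Within the data shown here, no measured pair shows what this particular change does, so the expectation can rest only on the two known numbers, which lie close together although their groups on the carbonyl carbon differ. On that basis the step of a 1.0-fold higher number from compound 1 to compound 3 (0.00 log units; within the scatter) is expected to be small, not beyond the scatter, in either direction. Compound 3 is therefore estimated to give about 1800 nM in this assay, with a plausible range from 700 nM to 4500 nM.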

Compound 3, concentration for 50% growth inhibition: 1590 nM
Compound 3: the middle estimate sits 1.1-fold (0.05 log units) above what was measured; the range from low to high includes it.
By their numbers in this assay, from the lowest: compounds 3, 2 and 1 (each within the scatter of the next).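

On the carbonyl carbon, putting 3,4-dimethoxyphenyl in place of 4-aminophenyl gives a 1.1-fold lower number from compound 1 to compound 3 (0.05 log units; within the scatter) in this assay. Within the data shown here, this is the first direct comparison at this position in which only one place differs, and it shows that these two groups cannot be told apart in this measurement, even though the entering group has more heavy atoms and no hydrogen-bond donor. No supporting measurement is available to explain why the two groups read alike.

From the compounds shown here alone, both groups compared here are six-membered aromatic rings of carbon only, so it remains open whether this position tolerates other kinds of group. A carboxylic acid or a short alkyl chain on this carbonyl carbon could read alike or differently, and the present numbers cannot say which.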